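From isopropyl to propyl on a sulfur

A few compounds are considered here, and "the series" means these few. Any claim that something is new, unique, unknown or untested is made for them only; others in the source may bear on it.

compound 1 `CCCSc1nc(Cc2c(F)cccc2Cl)cc(=O)[nH]1` reads > 80000 nM as a limit
compound 2 `CC(C)Sc1nc(C(C)c2c(F)cccc2Cl)cc(=O)[nH]1` reads > 75000 nM as a limit

In an ADME assay on MT4 cells (Homo sapiens) for activation, read by MTT assay (a higher number here means that more compound is tolerated, a lower number that less compound is tolerated), compound 2 gives > 75000 nM and this is a limit, not a number. Compound 1 also shows only a limit, so no exact gap between the two can be read.

Compound 3 (`CCCSc1nc(C(C)c2c(F)cccc2Cl)cc(=O)[nH]1`) has not been measured yet. Compared with compound 2, it carries propyl in place of isopropyl on a sulfur. The two have the same atoms, joined differently.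

Within the data shown here, no measured pair shows this change alone. Compound 1 also carries propyl on a sulfur, and its > 80000 nM is again a limit. No step beyond the usual scatter is therefore expected in this assay and compound 3 will probably report only a limit as well. The expected change (a step that the limit leaves unreadable from compound 2 to compound 3) is small. Should a number appear, compound 3 is estimated at 80000 nM (expected range 35000 nM to 160000 nM).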

Compound 3, half-maximal cytotoxic concentration: > 75000 nM
Compound 3 ended at the assay's limit; the forecaster's own chance of this, stated with the estimate: 75%; the middle value is on the limit's open side.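

In this assay compound 3 gives > 75000 nM, which is a limit and not a number. Among these compounds, compound 1, compound 2 and compound 3 all report only limits, so no step among them can be read. The compounds shown leave open the exact concentration each one reaches in this read-out, and whether either structural change shifts it at all.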